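Swapping Cyclopentyl for 3-Chlorophenyl on the Amide Carbonyl

The source may hold more compounds than are shown below. What is called first, only, known or untested is meant among the compounds shown, and "the series" means these compounds.

Three compounds sharing one core were tested in an assay on HEK293 cells for positive allosteric modulation of metabotropic glutamate receptor 5 (Homo sapiens), read by FLIPR, with a stated time of 1 h; on this read-out higher numbers stand for an effect only at larger amounts of compound and lower numbers for an effect already at smaller amounts; they differ only in the group attached to the carbonyl carbon of the amide. Compound 1 `CC1CC1C(=O)N1CCc2nc(C#Cc3ccccc3)sc2C1` carries a 2-methylcyclopropyl group and gives 9.4 nM. Compound 3 `O=C(C1CCCC1)N1CCc2nc(C#Cc3ccccc3)sc2C1` carries a cyclopentyl group and gives 19 nM, the higher of the two numbers measured; the gap to the nearest is a 2.0-fold higher number from compound 1 to compound 3 (0.31 log units; beyond the scatter). For compound 2 `O=C(C1CCC1)N1CCc2nc(C#Cc3ccccc3)sc2C1`, with a cyclobutyl group, the assay reports only a limit, > 10000 nM. The limit of > 10000 nM in this assay, at which 1 of the 3 values shown sits, is reached by a single compound here. The steps of an at least 1000-fold higher number from compound 1 to compound 2 (3.02 log units; beyond the scatter) and an at least 520-fold lower number from compound 2 to compound 3 (2.72 log units; beyond the scatter) are large, whereas a 2.0-fold higher number from compound 1 to compound 3 (0.31 log units; beyond the scatter) is modest, so the group on the carbonyl carbon can matter a great deal or very little.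

Compound 4 `O=C(c1cccc(Cl)c1)N1CCc2nc(C#Cc3ccccc3)sc2C1` has not been measured. It differs from compound 3 in one place: 3-chlorophenyl in place of cyclopentyl on a carbonyl carbon. Within the data shown here, no aromatic group at this position has been measured, so none of the three steps bears closely on this change; together they show only that a ring change here can be small or large. A modest step is expected for a 2.1-fold higher number from compound 3 to compound 4 (0.32 log units; beyond the scatter). In this assay compound 4 is estimated at 40 nM, within a range from 5 nM to 600 nM.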

Compound 4, half-maximal effective concentration: 8.7 nM
The estimate for compound 4 lay 4.6-fold (0.66 log units) above the measured number; measured number inside the range.
By their numbers in this assay, from the lowest: compounds 4 and 1 (each within the scatter of the next); then compound 3. At a limit, above all of these: compound 2.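

An aromatic ring on the carbonyl carbon, untested until now, is well accepted in this assay: replacing cyclopentyl with 3-chlorophenyl gives a 2.2-fold lower number from compound 3 to compound 4 (0.34 log units; beyond the scatter), a modest gain despite the change from a non-aromatic five-membered ring to an aromatic six-membered one. The new group cannot be told apart from 2-methylcyclopropyl, with a 1.1-fold lower number from compound 1 to compound 4 (0.03 log units; within the scatter), whereas the comparison with cyclobutyl gives an at least 1100-fold lower number from compound 2 to compound 4 (3.06 log units; beyond the scatter), so three quite different groups now sit within a modest span and cyclobutyl alone stands far away from them. Compound 2 remains the only compound whose value is a limit rather than a number, so that last step has no exact size: the limit of > 10000 nM in this assay, at which 1 of the 4 values shown sits.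

These compounds cannot separate what the aromatic ring contributes from what the chlorine contributes, and a plain phenyl group or a 3-methoxyphenyl group on the same carbonyl carbon would begin to address that. They also leave unexplained why cyclobutyl stands apart, and a cyclohexyl group or an open chain such as isopropyl would show whether that sharp loss is unique to cyclobutyl.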